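This account rests on a few compounds, and the source may have more. Where it says the series, first, only, none or still open, it means among the compounds named here.

Of the compounds shown here, two have so far been tested in a functional assay on NCI-H23 cells (Homo sapiens) for cytotoxicity, read by sulforhodamine B assay, with a stated time of 72 h; a higher number here means a weaker inhibitor of growth, a lower number a stronger inhibitor of growth. For compound 1 `O=C(Nc1ccccc1C(F)(F)F)c1ccc2ccccc2n1` the result is only a limit, > 90000 nM, and not a number. Compound 2 `CCCC(=O)N1c2ccccc2CCC1C(=O)Nc1ccccc1C(F)(F)F` keeps the same trifluoromethyl-bearing anilide but has a different core that carries a propylcarbonyl group. For compound 2 the result is likewise only a limit, > 70000 nM, with no number behind it. Compound 2 therefore stands at one of the two limits reported, (the limit of > 70000 nM in this assay, at which 1 of the 2 values shown sits). Compound 1 stands at the other, (the limit of > 90000 nM in this assay, at which 1 of the 2 values shown sits). Neither shows measurable growth inhibition within the range tested.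

Compound 3 `CC(=O)N1c2ccccc2CCC1C(=O)Nc1ccccc1C(F)(F)F` is the untested neighbour of compound 2: hydrogen in place of ethyl on a saturated chain carbon bound to a carbonyl carbon, so the propylcarbonyl becomes an acetyl. Among the measured compounds shown here, no measured pair shows what this change does. Given that compound 2 gives only > 70000 nM and compound 1 only > 90000 nM, removing the ethyl is not expected to move the number beyond the usual scatter. The step from compound 2 to compound 3 is estimated as a step that the limit leaves unreadable from compound 2 to compound 3. Compound 3 is expected to give 80000 nM, between 20000 nM and 200000 nM, and this assay will most likely again report only a limit.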

Compound 3, concentration for 50% growth inhibition: > 80000 nM
Compound 3: only a limit was reported; the forecaster's own chance of this, stated with the estimate: 85%; the middle value lies on the limit itself.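

Compound 2 and compound 3 both give only limits in this assay, so no size can be read for the change from propylcarbonyl to acetyl. The compounds shown leave open whether any change to these structures would give a real number in this assay, and what hydrogen in place of ethyl does to such a number.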